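The compounds below may be only part of what the source reports. "The series", "measured", "known", "first", "only" and "open" are said of these compounds alone.

Measured in (a functional assay on the whole organism with Rattus norvegicus as the target; on this read-out lower numbers stand for an effect already at smaller amounts and higher numbers for an effect only at larger amounts of compound):
- compound 1 `N#Cc1ccccc1OCC(O)CNCCC(=O)Nc1ccc(C2=NNC(=O)CC2)cc1` gives (1.7 umol/kg)
- compound 2 `CC1CC(=O)NN=C1c1ccc(NC(=O)CCNCC(O)COc2ccccc2C#N)cc1` gives (2.3 umol/kg)

Not yet measured: compound 3 `Cc1cccc(OCC(O)CNCCC(=O)Nc2ccc(C3=NNC(=O)CC3C)cc2)c1C`

For the measured compounds named here, compound 2 stands within the scatter of compound 1, the only other compound with a number so far. Compound 3 keeps the rest of compound 2 and carries one change (2,3-dimethylphenyl in place of 2-cyanophenyl on an oxygen on a saturated carbon), namely 2,3-dimethylphenyl in place of 2-cyanophenyl on an oxygen on a saturated carbon. Going by the values given here, the only measured step (a 1.4-fold higher number from compound 1 to compound 2 (0.13 log units; within the scatter)) is a methyl in place of hydrogen on a saturated ring carbon. Among the compounds with values here, it lies elsewhere in the molecule, so no measured step bears directly on this change, and its small size is only weak guidance. In (this assay) no step beyond the scatter is expected, though the data leave the direction open. The estimated step is (a 1.3-fold higher number from compound 2 to compound 3 (0.12 log units; within the scatter)) and carries wide uncertainty. Compound 3 is estimated at (3 umol/kg), with an expected range from (0.7 umol/kg) to (12 umol/kg).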

Compound 3, dose for half-maximal effect: 2.4 umol/kg
Compound 3: middle estimate off by 1.3-fold (0.10 log units), on the high side, within the range that was stated.
By their numbers in this assay, from the lowest: compounds 1, 2 and 3 (each within the scatter of the next).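

In this assay, for the compounds shown here, 2,3-dimethylphenyl in place of 2-cyanophenyl on an oxygen on a saturated carbon gives a 1.0-fold higher number from compound 2 to compound 3 (0.02 log units; within the scatter) and provides the first reading at this position, since the earlier step concerned a methyl on a saturated ring carbon. Here the nitrile and its hydrogen-bond acceptor are lost and two methyl groups enter at the same count of heavy atoms, yet the two compounds remain within the scatter of each other. Nothing on hand accounts for this close agreement.

As far as these compounds go, it remains open whether plain phenyl, or an aryl group carrying an amine or a carboxylic acid, would also stay within the scatter at this position. A longer chain between the phenoxy oxygen and the amine is equally untested by these compounds.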